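The source may report more compounds than this note shows. Statements on the series, on what has been measured and on what is new or still open speak of the compounds shown alone.

Series notes, read in a functional assay on MDA-MB-468 cells (Homo sapiens) for antiproliferative activity, read by sulforhodamine B assay, with a stated time of 4 days; on this read-out lower numbers stand for stronger inhibition of growth and higher numbers for weaker inhibition of growth:

compound 1, `COc1cc(Cl)c(-c2nc(SCC(=O)NC3CC3)nc3[nH]cc(C#N)c23)cc1OC`: 62 nM
compound 2, `COc1cc(Cl)c(-c2nc(SCC(=O)NC3CC3)nc3[nH]cc(C#N)c23)cc1O`: 236 nM
compound 3, `COc1cc(Cl)c(-c2nc(SCC(=O)N3CCC3)nc3[nH]cc(C#N)c23)cc1O`: 28 nM

Compound 2 is the common reference point for the two changes seen so far. The first change, from compound 2 to compound 1, is methyl in place of hydrogen on an oxygen on an aromatic ring; it gives a 3.8-fold lower number from compound 2 to compound 1 (0.58 log units; beyond the scatter). The second change, from compound 2 to compound 3, alters the amide portion: azetidin-1-yl in place of cyclopropylamino on a carbonyl carbon; it gives an 8.4-fold lower number from compound 2 to compound 3 (0.93 log units; beyond the scatter). Compound 3 thus stands with the lowest number of the three, compound 1 next, compound 2 furthest.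

Compound 4, `COc1cc(Cl)c(-c2nc(SCC(=O)N3CCC3)nc3[nH]cc(C#N)c23)cc1OC`, is not yet measured. It differs from compound 3 by methyl in place of hydrogen on an oxygen on an aromatic ring, which is the same change as that from compound 2 to compound 1, at a place described in identical words. Among the measured compounds shown here, the expectation for compound 4 in this assay is therefore a step of about a 3.1-fold lower number from compound 3 to compound 4 (0.49 log units; beyond the scatter), resting on the single earlier instance, a 3.8-fold lower number from compound 2 to compound 1 (0.58 log units; beyond the scatter), with allowance for it being only one example. The estimate for compound 4 is 9 nM, with a range from 4 nM to 25 nM.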

Compound 4, concentration for 50% growth inhibition: 35 nM
Compound 4: the middle estimate sits 3.9-fold (0.59 log units) below what was measured, outside the stated range (above it).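

On the azetidin-1-yl amide, methyl in place of hydrogen on the oxygen gives a 1.3-fold higher number from compound 3 to compound 4 (0.10 log units; within the scatter) in this assay, so the step seen on the cyclopropylamino amide does not carry over in size: the same change on two cores in this assay, a 3.8-fold lower number (0.58 log units; beyond the scatter) from compound 2 to compound 1 and a 1.3-fold higher number (0.10 log units; within the scatter) from compound 3 to compound 4, 4.8-fold (0.68 log units) apart, beyond the scatter of two such steps

Read the other way, azetidin-1-yl in place of cyclopropylamino gives a 1.8-fold lower number from compound 1 to compound 4 (0.25 log units; within the scatter) on the methoxy compounds, so that change also depends on its partner: the same change on two cores in this assay, an 8.4-fold lower number (0.93 log units; beyond the scatter) from compound 2 to compound 3 and a 1.8-fold lower number (0.25 log units; within the scatter) from compound 1 to compound 4, 4.8-fold (0.68 log units) apart, beyond the scatter of two such steps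

The two changes therefore do not add in this set of four compounds, but this single comparison does not show why they fail to add, nor whether the same holds anywhere else in the series.

Still open, going by these compounds, is whether the size of the hydroxy to methoxy step follows the amide more widely, for example with a pyrrolidin-1-yl or dimethylamino amide. Also open, on these data alone, is whether a longer chain on the oxygen, such as ethoxy, behaves like methoxy on either amide.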